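Aryl swap from compound 2 to compound 3

This account rests on a few compounds, and the source may have more. Where it says the series, first, only, none or still open, it means among the compounds named here.

Values measured in a functional assay on A549 cells (Homo sapiens) for cytotoxicity, read by MTT assay, with a stated time of 72 h (a higher number here means a weaker inhibitor, a lower number a stronger inhibitor), are as follows

compound 1 `O=C(N/N=C/c1ccc(F)cc1)Nc1cc2c(Nc3ccc(F)c(Cl)c3)ncnc2cc1O[C@H]1CCOC1` gives 35100 nM
compound 2 `N#Cc1ccc(/C=N/NC(=O)Nc2cc3c(Nc4ccc(F)c(Cl)c4)ncnc3cc2O[C@H]2CCOC2)cc1` gives 29100 nM

Compound 2 lies within the scatter of compound 1, so these two numbers do not rank the pair. The next compound is compound 3 `O=C(N/N=C/c1ccc(F)cc1Cl)Nc1cc2c(Nc3ccc(F)c(Cl)c3)ncnc2cc1O[C@H]1CCOC1` with the change 2-chloro-4-fluorophenyl in place of 4-cyanophenyl on a carbon with a double bond to nitrogen placing 2-chloro-4-fluorophenyl in place of 4-cyanophenyl on a carbon with a double bond to nitrogen. For the measured compounds named here, the only measured step is a 1.2-fold lower number from compound 1 to compound 2 (0.08 log units; within the scatter) with cyano in place of fluoro on an aromatic carbon, and it stayed within the scatter. Going by the values given here, it bears only partly on the new change, as no measured compound carries chloro on this aromatic ring. Among the compounds with values here, with that step as the sole guide, no shift beyond the scatter is expected in this assay for compound 3. An estimated 1.0-fold higher number from compound 2 to compound 3 (0.01 log units; within the scatter) would therefore stay within the scatter. For compound 3 the estimated value is 30000 nM with an expected range from 14000 nM to 60000 nM as its outer bounds.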

Compound 3, half-maximal inhibitory concentration: 27200 nM
Compound 3: the middle estimate sits 1.1-fold (0.04 log units) above what was measured; measured number inside the range.
By their numbers in this assay, from the lowest: compounds 3, 2 and 1 (each within the scatter of the next).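

In this assay, placing 2-chloro-4-fluorophenyl in place of 4-cyanophenyl on a carbon with a double bond to nitrogen gives a 1.1-fold lower number from compound 2 to compound 3 (0.03 log units; within the scatter), and chloro in place of hydrogen on an aromatic carbon gives a 1.3-fold lower number from compound 1 to compound 3 (0.11 log units; within the scatter). Chloro on this aromatic ring, absent from the earlier compounds, thus joins the fluoro-to-cyano change in leaving the number within the scatter, so compounds 1, 2 and 3 remain unranked. No supporting data bear on this result.

Still open, from the compounds shown here alone, is whether any group on this ring can move the number beyond the scatter, for example a dimethylamino group or a carboxylic acid. Also open, going by these compounds, is whether a longer chain in place of the aromatic ring would do so.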